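Thiophen-3-yl for 4-methoxyphenyl at the assay limit

The source may report more compounds than this note shows. Statements on the series, on what has been measured and on what is new or still open speak of the compounds shown alone.

Compound 1 `COc1ccc(-c2nc3ccccn3c2Sc2ccccc2)cc1`: > 100000 nM (a limit)
Compound 2 `c1ccc(Sc2c(-c3cccc4ccccc34)nc3ccccn23)cc1`: > 100000 nM (a limit)

In a functional assay on U-87MG ATCC cells for inhibition, with U-87 MG (Homo sapiens) as the target, read by MTT assay, with a stated time of 48 h (a lower number here means a stronger inhibitor, a higher number a weaker inhibitor), compound 1 gives > 100000 nM, which is a limit of the assay and not a number. Compound 2 gives > 100000 nM, which is also a limit. Compound 1 therefore has no exact value, and the data so far show only (the limit of > 100000 nM in this assay, at which 2 of the 2 values shown sit). Compound 3 `c1ccc(Sc2c(-c3ccsc3)nc3ccccn23)cc1` keeps the core of compound 1, with thiophen-3-yl in place of 4-methoxyphenyl on an aromatic carbon. Within the data shown here, no measured step shows the size of such a change, so none beyond the scatter is expected, and another limit is likely. The expected result is a number no higher from compound 1 to compound 3 (the limit leaves the size open). For compound 3 the estimated value is 100000 nM, with an expected range of 30000 nM to 200000 nM.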

Compound 3, half-maximal inhibitory concentration: 58600 nM
Estimate against measurement, compound 3: 1.7-fold (0.23 log units) above; the measured number falls inside the stated range.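

In this assay compound 3 gives an exact number, 58600 nM, so a group at this place on the shared core can bring a compound into the measurable range. Thiophen-3-yl in place of 4-methoxyphenyl gives an at least 1.7-fold lower number from compound 1 to compound 3 (0.23 log units; that floor lies within the scatter), and that is only a floor, so the true size of the step stays unknown. The other values shown offer no exact comparison: the limit of > 100000 nM in this assay, at which 2 of the 3 values shown sit.

The compounds shown leave open whether an amine or a carboxylic acid at this place would lower the number further. They also leave open what a methoxy group on the phenylsulfanyl ring would do.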